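Butyl in Place of Isopropyl on a Ring Nitrogen

The source may hold more compounds than are shown below. What is called first, only, known or untested is meant among the compounds shown, and "the series" means these compounds.

Of the compounds shown here, two have so far been measured in a functional assay on HCT-116 cells (Homo sapiens) for antiproliferative activity, read by CCK-8 assay, with a stated time of 72 h, tested at 8 uM; on this read-out lower numbers stand for a weaker effect and higher numbers for a stronger effect at the one concentration tested. Compound 2 `CC(C)n1cnc2c(Nc3ccccc3)nc(NCOCc3ccc(/C=C/C(=O)Nc4ccccc4N)cc3)nc21` gives 41.7%, the higher of the two numbers. Compound 1 `CCCCn1cnc2c(Nc3cccc(Cl)c3)nc(NCOCc3ccc(/C=C/C(=O)Nc4ccccc4N)cc3)nc21` gives 10.9%, and the gap between the two lies beyond the usual scatter of this read-out. Within the data shown here, compound 1 and compound 2 differ in more than one place, so no single structural step between measured compounds is available. Among the measured compounds shown here, the values show only that the pair spans a wide range.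

Compound 3 `CCCCn1cnc2c(Nc3ccccc3)nc(NCOCc3ccc(/C=C/C(=O)Nc4ccccc4N)cc3)nc21` has not yet been measured. It differs from compound 2 in one place: butyl in place of isopropyl on an aromatic nitrogen. Without any measured step of the same kind to rest on, only a cautious expectation is possible, and a modest downward step from compound 2 to compound 3 is expected, about a number 11.7 percentage points lower from compound 2 to compound 3 (beyond the scatter), with wide uncertainty in both directions. Compound 3 is therefore estimated at 30%, with a range from 10% to 50%.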

Compound 3, a percentage reported as inhibition, at one concentration (the size of the read-out at that concentration, not a potency): 51.9%
For compound 3 the middle estimate is 21.9 percentage points below the measured one, outside the stated range (above it).
By their numbers in this assay, from the lowest: compound 1; then compound 2; then compound 3.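

In this assay butyl in place of isopropyl on the aromatic nitrogen gives a number 10.2 percentage points higher from compound 2 to compound 3 (beyond the scatter) and so does not lower the read-out at this position. With butyl on that nitrogen in both compounds, hydrogen in place of chloro on an aromatic carbon gives a number 41 percentage points higher from compound 1 to compound 3 (beyond the scatter) and this large step, set against the modest one on the nitrogen, places the low number of compound 1 with the chloro and not with the butyl. No available evidence accounts for either step.

On these data alone, whether a longer chain such as hexyl or a ring such as cyclopentyl on the same nitrogen would carry the rise further remains open. So does whether fluoro or methoxy on that aromatic carbon would behave as chloro does.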